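The source may hold more compounds than are shown below. What is called first, only, known or untested is meant among the compounds shown, and "the series" means these compounds.

In a functional assay on cells (Burkitts lymphoma cell, Homo sapiens) for antiproliferative activity, read by MTT assay (on this read-out lower numbers stand for stronger inhibition and higher numbers for weaker inhibition), compound 1 `C/C(=N\Nc1nc2ccccc2o1)c1ccccn1` gives 9 nM. Compound 2 `CCC/C(=N\Nc1nc2ccccc2o1)c1ccccn1`, which carries a longer chain, gives 6 nM. This is a 1.5-fold lower number from compound 1 to compound 2 (0.18 log units; within the scatter), so compound 1 and compound 2 stand level. Compound 3 `CC(C)(C)/C(=N\Nc1nc2ccccc2o1)c1ccccn1`, with tert-butyl on the carbon with a double bond to nitrogen, reads > 10000 nM, which is a limit of the assay and not a number. Compound 1 is therefore far from compound 3, with an at least 1100-fold higher number from compound 1 to compound 3 (3.04 log units; beyond the scatter), and the gap is similar for an at least 1600-fold higher number from compound 2 to compound 3 (3.22 log units; beyond the scatter).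

Compound 4 `C/C(=N\Nc1nc2ccccc2o1)c1cccnc1` has the same atoms as compound 1, joined differently: pyridin-3-yl in place of pyridin-2-yl on a carbon with a double bond to nitrogen. Among the compounds with values here, no measured step changes this ring, so the evidence is indirect. Within the data shown here, the steps to compound 3 show only that a change on this same carbon can move the number greatly, while the step to compound 2 shows that it need not. A large rise in the number is expected in this assay, but with wide uncertainty, and the estimate is a 110-fold higher number from compound 1 to compound 4 (2.05 log units; beyond the scatter). Compound 4 is expected at 1000 nM, with an estimated range of 60 nM to 10000 nM.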

Compound 4, half-maximal inhibitory concentration: > 100000 nM
Compound 4: no number, only a limit; the forecaster's own chance of this, stated with the estimate: 20%; middle value at least 100-fold (2.00 log units) away from the limit.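

In this assay, placing pyridin-3-yl instead of pyridin-2-yl on the carbon with a double bond to nitrogen gives an at least 11000-fold higher number from compound 1 to compound 4 (4.04 log units; beyond the scatter), although the two groups have the same atoms and the same counts of donors and acceptors. The earlier compounds shown here showed only that the chain on this carbon can matter, with methyl and propyl level and tert-butyl far off; this result shows that the ring on the same carbon matters too, and that the way it is joined is enough to change the read-out greatly. For compound 4 there is no number, only a limit of the assay: the limit of > 100000 nM in this assay, at which 1 of the 4 values shown sits.

As far as these compounds go, whether a phenyl ring in this place would keep any activity remains open, and so does whether the ring nitrogen is needed at all. Also open, from the compounds shown here alone, is whether pyridin-3-yl would give the same result with propyl on this carbon instead of methyl.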